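Cyclopropylamino to methylamino on the shared core

A few compounds are considered here, and "the series" means these few. Any claim that something is new, unique, unknown or untested is made for them only; others in the source may bear on it.

Measured so far:
compound 1, `O=S(=O)(Nc1ccc(CNc2nc(NC3CC3)nc3ccccc23)cc1)c1ccc(F)cc1`, 4100 nM
compound 2, `CNc1nc(NCc2ccc(C(=O)NC3CCN(Cc4ccc(F)cc4)CC3)cc2)c2cc(C)ccc2n1`, 1300 nM

Two compounds carry numbers in a functional assay on SW480 cells (Homo sapiens) for inhibition, read by luminescence and resazurin assay, with a stated time of 3 days; a higher number here means a weaker inhibitor, a lower number a stronger inhibitor. Compound 1 gives 4100 nM, the higher of the two; compound 2 gives 1300 nM, and the gap between them lies beyond the usual scatter. Among the measured compounds shown here, compound 2 differs from compound 1 in several places at once, so the two values show only that compound 1 is the weaker inhibitor of the pair and nothing about any single change.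

Compound 3, `CNc1nc(NCc2ccc(NS(=O)(=O)c3ccc(F)cc3)cc2)c2ccccc2n1`, has not been measured. It differs from compound 1 by methyl in place of cyclopropyl on a nitrogen on an aromatic ring: cyclopropylamino becomes methylamino. For the measured compounds named here, no step between measured compounds isolates this change. Compound 2 also carries methylamino and shows the lower number, but its other differences from compound 1 leave that observation unassigned.

The expectation for compound 3 is a small step, a 1.4-fold lower number from compound 1 to compound 3 (0.14 log units; within the scatter), toward a lower number, likely within the scatter. Compound 3 is estimated at 3000 nM, with a range of 1000 nM to 9000 nM.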

Compound 3, half-maximal inhibitory concentration: 4800 nM
Compound 3: middle estimate off by 1.6-fold (0.20 log units), on the low side; measured number inside the range.
By their numbers in this assay, from the lowest: compound 2; then compounds 1 and 3 (each within the scatter of the next).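

In this assay, among the compounds shown here, this is the first step that isolates the position, and it reads a 1.2-fold higher number from compound 1 to compound 3 (0.07 log units; within the scatter). On the shared core, with all else held constant, methyl in place of cyclopropyl on this nitrogen therefore leaves the number within the scatter, and the ring is not needed to hold the value in this assay. No supporting measurement bears on why cyclopropylamino and methylamino read alike here.

As far as these compounds go, the step was read only with the rest of compound 1 in place, so it remains open whether the two groups also read alike with the other parts of compound 2, which carries methylamino and differs from compound 1 in several places. Also open, from the compounds shown here alone, is how this nitrogen responds to a plain amino group, to ethylamino or dimethylamino, or to a longer chain such as butylamino, since a single step between a small ring and a methyl gives no trend for the position.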